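Removing the benzyl group from compound 1

The compounds below may be only part of what the source reports. "The series", "measured", "known", "first", "only" and "open" are said of these compounds alone.

Measured in a functional assay on MCF7 cells (Homo sapiens) for inhibition, read by trypan blue exclusion, with a stated time of 72 h; on this read-out higher numbers stand for weaker inhibition of growth and lower numbers for stronger inhibition of growth:
Compound 1 `CC/C(=C(\c1ccccc1)c1ccc(NC(=O)C(C)C)cc1)c1ccc(OCc2ccccc2)cc1`: > 30000 nM (a limit of the assay)
Compound 2 `CC/C(=C(/c1ccc(NC(=O)C(C)C)cc1)c1ccc(OC)cc1)c1ccc(OCc2ccccc2)cc1`: 29000 nM

Compound 1 stands at the limit of > 30000 nM in this assay, at which 1 of the 2 values shown sits. That is a limit and not a number.

Compound 3 `CC/C(=C(\c1ccccc1)c1ccc(NC(=O)C(C)C)cc1)c1ccc(O)cc1` differs from compound 1 in one place: hydrogen in place of benzyl on an oxygen on an aromatic ring. This is hydrogen in place of benzyl on an oxygen on an aromatic ring, so benzyloxy becomes hydroxy.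

Among the compounds with values here, the one measured step is an at least 1.0-fold lower number from compound 1 to compound 2 (0.01 log units; that floor lies within the scatter). It is a different change, methoxy in place of hydrogen on an aromatic carbon, and compound 2 keeps its benzyl. Within the data shown here, that step therefore bears on the new change only weakly, and no measured compound lacks the benzyl.

Compound 1 has only a limit to start from, so a measured number for compound 3 would be expected to fall on the lower side in this assay, meaning stronger inhibition of growth. The size is uncertain, and the result could also stay at the limit. The expected step is an at least 3.7-fold lower number from compound 1 to compound 3 (0.57 log units; beyond the scatter). The estimated value for compound 3 is 8000 nM, with an expected range from 1500 nM to 30000 nM.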

Compound 3, concentration for 50% growth inhibition: 8100 nM
Compound 3: the middle estimate sits 1.0-fold (0.01 log units) below what was measured; measured number inside the range.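

In this assay, replacing the benzyl on the oxygen with hydrogen, so that benzyloxy becomes hydroxy, gives an at least 3.7-fold lower number from compound 1 to compound 3 (0.56 log units; beyond the scatter). This shows that the benzyl is not required for growth inhibition in this pair: the core of compound 1 with a plain hydroxy at this oxygen gives a real number, and the step lies beyond the usual scatter, which the earlier methoxy step could not be shown to do. The step is only a floor and its full size stays unknown, because compound 1 has a limit of the assay rather than a number: the limit of > 30000 nM in this assay, at which 1 of the 3 values shown sits.

The compounds shown cannot separate what the free hydroxy contributes from what is gained by losing the benzyl, and a methoxy or a longer chain such as butoxy on the same oxygen would help to tell these two apart. They also leave open whether the same change would lower the number for compound 2, which carries a methoxy on its aromatic ring and keeps its benzyl.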